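Swapping an Aromatic Ring for Cyclopropyl at the Alkyne

The source may hold more compounds than are shown below. What is called first, only, known or untested is meant among the compounds shown, and "the series" means these compounds.

Of the compounds shown here, two have been measured in an assay on CHO cells for displacement of a labelled ligand from adenosine receptor A1 (Homo sapiens), read by scintillation counting, with a stated time of 60 min, tested at 10 uM; on this read-out higher numbers stand for more inhibition at the one concentration tested (going by the name of the read-out) and lower numbers for less inhibition. Compound 2 `CNC(=O)[C@@]12C[C@@H]1[C@@H](n1cnc3c(NC)nc(C#Cc4ccsc4)nc31)[C@H](O)[C@@H]2O` gives 11%, the smaller of the two numbers shown, while compound 1 `CCc1ccc(C#Cc2nc(NC)c3ncn([C@H]4[C@H](O)[C@H](O)[C@]5(C(=O)NC)C[C@H]45)c3n2)o1` gives 18%, a gap that stays within the usual scatter. Compound 3 `CNC(=O)[C@@]12C[C@@H]1[C@@H](n1cnc3c(NC)nc(C#CC4CC4)nc31)[C@H](O)[C@@H]2O` differs from compound 2 in one place: cyclopropyl in place of thiophen-3-yl on a triple-bonded carbon. Among the compounds with values here, the one step that speaks to this site is a number 7 percentage points lower from compound 1 to compound 2 (within the scatter), also on a triple-bonded carbon. Because a number 7 percentage points lower from compound 1 to compound 2 (within the scatter) stayed within the scatter, no step beyond the scatter is expected here either: a number 1 percentage points lower from compound 2 to compound 3 (within the scatter). Compound 3 is therefore estimated at 10%, between 0% and 25%.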

Compound 3, a percentage reported as inhibition, at one concentration (the size of the read-out at that concentration, not a potency): 38%
Compound 3: middle estimate off by 28 percentage points, on the low side, and the stated range ends below it.
By their numbers in this assay, from the lowest: compounds 2 and 1 (each within the scatter of the next); then compound 3.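

Swapping either ring for cyclopropyl on the triple-bonded carbon moves the read-out in this assay beyond the scatter, which the thiophen-3-yl and 5-ethylfuran-2-yl pair did not do. Replacing thiophen-3-yl gives a number 27 percentage points higher from compound 2 to compound 3 (beyond the scatter), and replacing 5-ethylfuran-2-yl gives a number 20 percentage points higher from compound 1 to compound 3 (beyond the scatter). No measurement shown explains this rise.

From the compounds shown here alone, whether other non-aromatic groups at this place, such as a cyclopentyl ring or an open propyl chain, behave like cyclopropyl remains open. These readings also come from one concentration, so they give no potency.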